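This account rests on a few compounds, and the source may have more. Where it says the series, first, only, none or still open, it means among the compounds named here.

Measured compounds:
Compound 1, `Cc1ccc(-c2noc(-c3cc(O)c(O)c([N+](=O)[O-])c3)n2)c(Cl)[n+]1[O-]`, 31.6%
Compound 2, `O=[N+]([O-])c1cc(-c2nc(-c3ccc[n+]([O-])c3Cl)no2)cc(O)c1O`, 71.6%
Compound 3, `Cc1c(-c2noc(-c3cc(O)c(O)c([N+](=O)[O-])c3)n2)ccc(C(F)(F)F)[n+]1[O-]`, 13.9%

All three were tested in a functional assay on the whole organism (liver, strain Wistar) for inhibition, with Rattus norvegicus as the target, with a stated time of 3 h, at a dose of 3 mg/kg by the oral route; on this read-out higher numbers stand for more inhibition at the one dose given (going by the name of the read-out) and lower numbers for less inhibition. Compound 2 stands highest, compound 3 lowest. Between compound 1 and compound 2 the only change is hydrogen in place of methyl on an aromatic carbon, and this change produced a number 40 percentage points higher from compound 1 to compound 2 (beyond the scatter).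

Compound 4, `O=[N+]([O-])c1cc(-c2nc(-c3ccc(C(F)(F)F)[n+]([O-])c3)no2)cc(O)c1O`, has not yet been measured in this assay . It differs from compound 3 by hydrogen in place of methyl on an aromatic carbon. Going by the values given here, this is the same kind of change as the one from compound 1 to compound 2, though the surroundings differ: in compound 1 the place is meta to a chloro group and para to a large group, whereas in compound 3 it is ortho to a large group and meta to a trifluoromethyl group. How the core of compound 3 differs from the core of compound 1 is not broken down here.

Resting on the single earlier step, compound 4 is expected to rise from compound 3 by a number 31.1 percentage points higher from compound 3 to compound 4 (beyond the scatter), a rise somewhat smaller than the earlier one to allow for the different surroundings. The estimate for compound 4 in this assay is 45%, with a range from 20% to 70%.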

Compound 4, a percentage reported as inhibition, in the whole organism at one dose (the size of the read-out at that dose, not a potency): 34.4%
Compound 4: middle estimate off by 10.6 percentage points, on the high side; the measured number falls inside the stated range.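

In this assay, hydrogen in place of methyl on an aromatic carbon again produced a higher number, a number 20.5 percentage points higher from compound 3 to compound 4 (beyond the scatter), so the direction of this change carries over from the core of compound 1 to the core of compound 3. Its size does not carry over, as the two steps differ by more than the scatter allows: the same change on two cores in this assay, a number 40 percentage points higher (beyond the scatter) from compound 1 to compound 2 and a number 20.5 percentage points higher (beyond the scatter) from compound 3 to compound 4, 19.5 percentage points apart, beyond the scatter of two such steps. Two steps on two cores show only that the gain depends on the core; they do not tell which feature of the core sets its size, nor how large the step would be on a third core.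

The compounds shown carry only methyl or hydrogen at this place, so it remains open how an ethyl group, a methoxy group or an amine there would read in this assay. Also open, going by these compounds, is how the step would run with a nitrile or a carboxylic acid in place of the trifluoromethyl group.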